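Swapping the fluorinated aryl arm of compound 2

The source may hold more compounds than are shown below. What is called first, only, known or untested is meant among the compounds shown, and "the series" means these compounds.

Three analogues sharing one core have been tested in a functional assay on DU-145 cells (Homo sapiens) for inhibition; a lower number here means a stronger inhibitor, a higher number a weaker inhibitor. Compound 1 `Oc1ccc(-c2cc(-c3ccccc3F)cc(-c3cccc(O)c3)n2)cc1` gives 3160 nM, and compound 3 `Oc1cccc(-c2cc(-c3ccccc3C(F)(F)F)cc(-c3cccc(O)c3)n2)c1` gives 2870 nM. Within the data shown here, compound 2 `Oc1ccc(-c2cc(-c3ccccc3F)cc(-c3ccc(O)cc3)n2)cc1` gives 7780 nM, the highest number of the three; the single measured step, a 2.5-fold higher number from compound 1 to compound 2 (0.39 log units; beyond the scatter), runs to it from compound 1. Compound 4 `Oc1ccc(-c2cc(-c3ccc(C(F)(F)F)cc3)cc(-c3ccc(O)cc3)n2)cc1` is the untested member: it carries 4-(trifluoromethyl)phenyl in place of 2-fluorophenyl on an aromatic carbon. Among the measured compounds shown here, no measured step bears directly on this change. Compound 1 and compound 3 differ in two places, but their values show that a fluorine on one arm and a trifluoromethyl on that arm sit within the scatter of each other, which suggests a small shift at most. In this assay compound 4 is therefore expected to give 6000 nM, within a range of 2000 nM to 18000 nM. The expected step from compound 2 is estimated as a 1.3-fold lower number from compound 2 to compound 4 (0.11 log units; within the scatter), which would lie within the usual scatter.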

Compound 4, half-maximal inhibitory concentration: > 50000 nM
Compound 4: a limit, no number; the forecaster's own chance of this, stated with the estimate: 10%; at least 8.3-fold (0.92 log units) between middle value and limit.
By their numbers in this assay, from the lowest: compounds 3 and 1 (each within the scatter of the next); then compound 2. At a limit, above all of these: compound 4.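

In this assay compound 4 gives > 50000 nM, which is a limit of the assay and not a number. Among these compounds, the aryl group on the aromatic carbon opposite the ring nitrogen therefore matters, a point the earlier compounds could not show: 4-(trifluoromethyl)phenyl in place of 2-fluorophenyl gives an at least 6.4-fold higher number from compound 2 to compound 4 (0.80 log units; beyond the scatter). The true size of this step remains unknown, since the reading ends at a limit: the limit of > 50000 nM in this assay, at which 1 of the 4 values shown sits.

The swap both replaces fluorine with trifluoromethyl and changes where the substituent sits on the phenyl ring, and the compounds shown do not separate these two changes. On these data alone, how a phenyl ring carrying an amine or a carboxylic acid would read at this position in this assay also stays open.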